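A few compounds are considered here, and "the series" means these few. Any claim that something is new, unique, unknown or untested is made for them only; others in the source may bear on it.

Compound 1 `COc1ccc(Cn2c(=O)n(C3OC(CO)[C@@H](O)[C@H]3O)c3nc(N)nc(O)c32)cc1` is measured in a functional assay (B cells) with Mus musculus as the target (on this read-out lower numbers stand for an effect already at smaller amounts and higher numbers for an effect only at larger amounts of compound), where compound 1 gives 135 uM. Among the three numbers shown, compound 1 stands second highest. Its nearest neighbour, compound 2 `CN(C)CCCn1c(=O)n(C2OC(CO)[C@@H](O)[C@H]2O)c2nc(N)nc(O)c21`, gives 194 uM, a difference described as a 1.4-fold higher number from compound 1 to compound 2 (0.16 log units; within the scatter). Compound 3 `CCOC(=O)Cn1c(=O)n(C2OC(CO)[C@@H](O)[C@H]2O)c2nc(N)nc(O)c21` gives 48 uM, and the step is a 2.8-fold lower number from compound 1 to compound 3 (0.45 log units; beyond the scatter); between the other two it is a 4.0-fold lower number from compound 2 to compound 3 (0.61 log units; beyond the scatter).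

Compound 4 `Nc1nc(O)c2c(n1)n(C1OC(CO)[C@@H](O)[C@H]1O)c(=O)n2Cc1ccc(OCc2ccccc2)cc1` differs from compound 1 only by phenyl in place of hydrogen on a saturated chain carbon bound to an oxygen on an aromatic ring. All three measured steps change the group on the saturated chain carbon bound to the aromatic nitrogen, so none of them touches the place that is changed in compound 4. Among the measured compounds shown here, the data therefore hold no step that bears on this change, and the three values spread only modestly. With no guide, the number for compound 4 is expected to stay close to that of compound 1, with a step of about a 1.1-fold lower number from compound 1 to compound 4 (0.05 log units; within the scatter), and either direction within a wide margin is possible. Compound 4 is estimated at 120 uM, within a range from 35 uM to 400 uM.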

Compound 4, concentration for half-maximal effect: 8 uM
Compound 4: the middle estimate sits 15-fold (1.18 log units) above what was measured, and the stated range ends above it.
By their numbers in this assay, from the lowest: compound 4; then compound 3; then compounds 1 and 2 (each within the scatter of the next).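

In this assay, adding a phenyl on the saturated chain carbon bound to an oxygen on an aromatic ring, which turns methoxy into benzyloxy, gives a 17-fold lower number from compound 1 to compound 4 (1.23 log units; beyond the scatter) and so marks this place as highly sensitive to change. The earlier steps shown here left this place untouched, and the largest of them, changing the group on the saturated chain carbon bound to the aromatic nitrogen, was only a 4.0-fold lower number from compound 2 to compound 3 (0.61 log units; beyond the scatter) in size. Nothing shown explains why the added phenyl has so large an effect.

Going by these compounds, this place is represented by just one step, so it remains open whether the phenyl ring itself is needed or a longer chain such as propyl would serve as well. On these data alone, it is also open how an amine or a carboxylic acid at the end of that chain would read out.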